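Bromine for fluorine on the phenyl ring of compound 3

The source may report more compounds than this note shows. Statements on the series, on what has been measured and on what is new or still open speak of the compounds shown alone.

Three compounds share one core and differ only in the aryl group on the double-bonded chain carbon. In an assay (Equus caballus) for inhibition of Thromboxane-A synthase (Homo sapiens), using microsomes (on this read-out higher numbers stand for weaker inhibition and lower numbers for stronger inhibition), compound 1 `Cc1ccsc1/C(=C/CCCCC(=O)O)c1cccnc1` gives 29 nM, compound 2 `O=C(O)CCCC/C=C(\c1cccnc1)c1ccsc1` gives 31 nM, and compound 3 `O=C(O)CCCC/C=C(/c1ccc(F)cc1)c1cccnc1` gives 83 nM. Compound 3 therefore stands at the highest of the three numbers, with a 2.9-fold higher number from compound 1 to compound 3 (0.46 log units; beyond the scatter) and a 2.7-fold higher number from compound 2 to compound 3 (0.43 log units; beyond the scatter), both modest but beyond the scatter, while a 1.1-fold higher number from compound 1 to compound 2 (0.03 log units; within the scatter) lies within it.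

Compound 4 `O=C(O)CCCC/C=C(/c1ccc(Br)cc1)c1cccnc1` takes the step (bromo in place of fluoro on an aromatic carbon). Going by the values given here, no measured step in this set exchanges one halogen for another on this phenyl ring; the two steps that reach compound 3 only trade a thiophene for the fluorophenyl, and they say nothing about how a heavier halogen at the same place behaves. On that basis compound 4 is expected to stay close to compound 3, with a step of a 1.0-fold lower number from compound 3 to compound 4 (0.02 log units; within the scatter) that may well fall inside the scatter. The estimate for compound 4 in this assay is 80 nM, with a range from 30 nM to 250 nM.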

Compound 4, half-maximal inhibitory concentration: 82 nM
Estimate against measurement, compound 4: 1.0-fold (0.01 log units) below, and the stated range covers the measured number.
By their numbers in this assay, from the lowest: compounds 1 and 2 (each within the scatter of the next); then compounds 4 and 3 (each within the scatter of the next).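

In this assay the swap of one halogen for another on this phenyl ring gives a 1.0-fold lower number from compound 3 to compound 4 (0.01 log units; within the scatter) so on this aromatic carbon, para to a large group, fluoro and bromo cannot be told apart. The thiophene compounds remain apart from the 4-bromophenyl compound, with a 2.6-fold higher number from compound 2 to compound 4 (0.42 log units; beyond the scatter) and a 2.8-fold higher number from compound 1 to compound 4 (0.45 log units; beyond the scatter) as modest steps beyond the scatter, and so the separation seen with the 4-fluorophenyl group in compound 3 also holds with the 4-bromophenyl group. Nothing available here explains why the two halogens read alike.

Going by these compounds, whether a methoxy group or an amine on this same aromatic carbon would also leave the number unmoved stays open. So does the response to a shorter chain carrying the carboxylic acid.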